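From a Triazole to an Oxadiazolone in EP3 Antagonists

This account rests on a few compounds, and the source may have more. Where it says the series, first, only, none or still open, it means among the compounds named here.

Compound 1, `CC(C)C(O)(C(=O)O)c1ccc(-c2ccc3ccccc3c2)[nH]c1=O`, gives 1580 nM.
Compound 2, `CC(C)C(Cc1nnc[nH]1)c1ccc(-c2ccc3cccc(F)c3c2)[nH]c1=O`, gives 17 nM.
Compound 3, `CCC(CC)(c1nnc[nH]1)c1ccc(-c2ccc3cccc(F)c3c2)[nH]c1=O`, gives 36 nM.

These three values come from a functional assay on CHO cells for antagonist activity at prostaglandin E2 receptor EP3 subtype (Homo sapiens), read by cAMP accumulation; a lower number here means a stronger inhibitor, a higher number a weaker inhibitor. Compound 2 stands lowest of the three numbers: compound 3 sits beyond the usual scatter above it, and compound 1 sits far above it. Compound 1 differs from compound 2 in several places at once, so its much higher number cannot be tied to any single group.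

The unmeasured compound 4 is `CC(C)C(Cc1noc(=O)[nH]1)c1ccc(-c2ccc3cccc(F)c3c2)[nH]c1=O`. Compared with compound 2 it carries a group of 6 heavy atoms (2 carbon, 2 nitrogen, 2 oxygen; one five-membered aromatic ring with 3 hetero atoms) in place of a group of 5 heavy atoms (2 carbon, 3 nitrogen; one five-membered aromatic ring with 3 hetero atoms), on a saturated chain carbon, two bonds along the chain from an aromatic carbon. Both the group that leaves and the group that enters are small five-membered rings with a single hydrogen-bond donor, so the shape of the side chain is largely kept. Among the measured compounds shown here, no measured pair in this set isolates this exchange, so the expected step rests only on the general closeness of the two groups.

The step of a 1.8-fold higher number from compound 2 to compound 4 (0.25 log units; within the scatter) is expected to be small, most likely a modest weakening that may or may not exceed the scatter. Compound 4 is therefore expected to give about 30 nM in this assay, with a likely range from 8 nM to 120 nM.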

Compound 4, half-maximal inhibitory concentration: 70 nM
For compound 4 the middle estimate is 2.3-fold (0.37 log units) below the measured one; low and high end bracket the measured number.
By their numbers in this assay, from the lowest: compound 2; then compounds 3 and 4 (each within the scatter of the next); then compound 1.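

In this assay, exchanging the 4H-1,2,4-triazol-3-yl on the saturated chain carbon for the oxadiazolone ring gives a 4.1-fold higher number from compound 2 to compound 4 (0.61 log units; beyond the scatter), so this place on the side chain does respond to which ring it carries, even though both rings are five-membered and aromatic, with three hetero atoms and one hydrogen-bond donor. The step is modest, so this single pair shows that the oxadiazolone can stand in this place but does not match the triazole here. The entering ring has one more heavy atom, one more hydrogen-bond acceptor and a double bond outside the aromatic ring, and one pair cannot separate these differences; no measurement here gives a reason for the step.

Whether the same exchange would give a similar step on the side chain of compound 3 stays open, since that compound has no oxadiazolone partner among those shown. Also open, going by these compounds, is how a tetrazole or a primary amide would compare with these two rings at this same place on the chain.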